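Trifluoromethyl in Place of Chloro: An Open Question

A few compounds are considered here, and "the series" means these few. Any claim that something is new, unique, unknown or untested is made for them only; others in the source may bear on it.

In a functional assay on HO8910 cells (Homo sapiens) for inhibition, read by MTT assay, with a stated time of 24 h, tested at 10 ug/mL (on this read-out higher numbers stand for more inhibition of growth at the one concentration tested and lower numbers for less inhibition of growth), compound 1 (`O=C(CCCCC1CCSS1)Nc1cccc(C(F)(F)F)c1`) gives 5.99% at the one concentration tested. Compound 2 (`O=C(CCCCC(S)CCS)Nc1cccc(Cl)c1`) is reported as "not active" (no number reported) in this assay with no single number attached. Compound 3 (`O=C(CCCCC(S)CCS)Nc1cccc(C(F)(F)F)c1`) has not yet been measured. The structural change is trifluoromethyl in place of chloro on an aromatic carbon and amounts to trifluoromethyl in place of chloro on an aromatic carbon. Among the measured compounds shown here, no measured pair shows the effect of this swap, so no step beyond the usual scatter is expected in this assay here. Compound 3 is estimated at 6% within an expected range of 0% to 20% on this scale.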

Compound 3, percent growth inhibition at one concentration: 8.86%
Compound 3: the middle estimate sits 2.9 percentage points below what was measured; the range from low to high includes it.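

In this assay, the open chain in place of the five-membered non-aromatic ring gives a number 2.9 percentage points higher from compound 1 to compound 3 (within the scatter), so with trifluoromethyl on the aromatic ring the two forms of the chain are not told apart. On these data alone, the step from compound 2 to compound 3 cannot be read, since compound 2 carries no number, and the size of trifluoromethyl in place of chloro stays unknown. Nothing available accounts for these results. Still open, as far as these compounds go, is how a nitrile at the same aromatic carbon would read, or a longer chain in place of the present one.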